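A few compounds are considered here, and "the series" means these few. Any claim that something is new, unique, unknown or untested is made for them only; others in the source may bear on it.

Measured compounds:
compound 1 `O=C(/C(=C\c1ccc(Br)cc1)Sc1ccc(Br)cc1)c1ccc(Br)cc1` gives 1000 nM
compound 2 `O=C(/C(=C\c1ccc(Br)cc1)Sc1ccccc1Br)c1ccc(Br)cc1` gives 1000 nM
compound 3 `O=C(/C(=C\c1c(O)cc(O)cc1O)Sc1ccc(Br)cc1)c1ccc(Cl)cc1` gives 50000 nM

In a functional assay on DU-145 cells (Homo sapiens) for inhibition, read by trypan blue exclusion, with a stated time of 96 h (on this read-out lower numbers stand for stronger inhibition of growth and higher numbers for weaker inhibition of growth), compound 1 and compound 2 differ only by 2-bromophenyl in place of 4-bromophenyl on a sulfur, and the step of no change at the digits printed from compound 1 to compound 2 (within the scatter). Compound 3 stands apart, with the highest of the three numbers; how its core differs from that of compound 1 is not broken down here. Compound 4 `O=C(/C(=C\c1c(O)cc(O)cc1O)Sc1ccccc1Br)c1ccc(Cl)cc1` has not been measured in this assay. It differs from compound 3 by 2-bromophenyl in place of 4-bromophenyl on a sulfur, the same change, in the same place, as that from compound 1 to compound 2. Going by the values given here, since that earlier step is no change at the digits printed from compound 1 to compound 2 (within the scatter), the step from compound 3 to compound 4 is expected to be similarly small, no change at the digits printed from compound 3 to compound 4 (within the scatter), though the rest of the core differs and only one such pair is known. Compound 4 is therefore estimated at 50000 nM, between 20000 nM and 125000 nM.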

Compound 4, concentration for 50% growth inhibition: > 100000 nM
Compound 4: a limit, no number; the forecaster's own chance of this, stated with the estimate: 15%; at least 2.0-fold (0.30 log units) between middle value and limit.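

In this assay compound 4 gives > 100000 nM, which is a limit of the assay and not a number. The step therefore reads only as an at least 2.0-fold higher number from compound 3 to compound 4 (0.30 log units; that floor lies within the scatter), and set beside the earlier pair it leaves the comparison undecided: the same change on two cores in this assay, no change at the digits printed (within the scatter) from compound 1 to compound 2 and an at least 2.0-fold higher number (0.30 log units; that floor lies within the scatter) from compound 3 to compound 4; the limit leaves it open whether they differ The series thus shows 2-bromophenyl in place of 4-bromophenyl on a sulfur on two cores, but it does not show whether the change carries over unaltered from one core to the other or behaves differently on each. The compounds shown leave open whether the result goes with the hydroxyl groups or the chlorine of the second core, and how the change would read with an amine or a carboxylic acid in place of the bromine.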